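Removing the pentyl chain from a pyranosyl alkynyl nucleoside

The source may hold more compounds than are shown below. What is called first, only, known or untested is meant among the compounds shown, and "the series" means these compounds.

Compound 1 `CCCCCC#Cc1cn([C@@H]2O[C@H](CO)[C@@H](O)[C@H](O)[C@H]2O)c(=O)nc1N` — >= 250000 nM
Compound 2 `CCCCCc1ccc(C#Cc2cn([C@@H]3O[C@H](CO)[C@@H](O)[C@H](O)[C@H]3O)c(=O)nc2O)cc1` — 31000 nM
Compound 3 `CC(C)(C)c1ccc(C#Cc2cn([C@@H]3O[C@H](CO)[C@@H](O)[C@H](O)[C@H]3O)c(=O)nc2O)cc1` — 37000 nM

In a functional assay on HeLa cells (Homo sapiens) for cytotoxicity, with a stated time of 72 h (on this read-out lower numbers stand for stronger inhibition and higher numbers for weaker inhibition), compound 1 sits only at a limit of the assay, >= 250000 nM, so no number is known for it. Within the data shown here, compound 2 gives 31000 nM in this assay, and compound 3 gives 37000 nM; the step of a 1.2-fold higher number from compound 2 to compound 3 (0.08 log units; within the scatter) is the only measured step, and it concerns a different core and a substituent on an aromatic carbon, so it does not bear on the change now in question. That change leads to compound 4 `C#Cc1cn([C@@H]2O[C@H](CO)[C@@H](O)[C@H](O)[C@H]2O)c(=O)nc1N`, which differs from compound 1 by hydrogen in place of pentyl on a triple-bonded carbon. With compound 1 defined only by the limit of >= 250000 nM in this assay, at which 1 of the 3 values shown sits, the size of the step to compound 4 cannot be anchored from either side, and the two aryl compounds give no guidance on a terminal ethynyl group. Compound 4 is therefore expected to remain weak, with the step of an at least 1.2-fold lower number from compound 1 to compound 4 (0.09 log units; that floor lies within the scatter) most likely again ending at the limit of this assay. The estimate for compound 4 is 200000 nM, with a range from 50000 nM to 250000 nM.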

Compound 4, half-maximal inhibitory concentration: >= 250000 nM
Compound 4: a limit, no number; the forecaster's own chance of this, stated with the estimate: 70%; middle value at least 1.2-fold (0.09 log units) from the limit.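

Compound 4 gives only a limit in this assay, as compound 1 does, so no step between them can be read: the limit of >= 250000 nM in this assay, at which 2 of the 4 values shown sit.

The compounds shown leave open whether hydrogen in place of pentyl on a triple-bonded carbon changes the result in this assay at all.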